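This account rests on a few compounds, and the source may have more. Where it says the series, first, only, none or still open, it means among the compounds named here.

Measured in a functional assay for inhibition of sodium/hydrogen exchanger (Oryctolagus cuniculus); a higher number here means a weaker inhibitor, a lower number a stronger inhibitor:

Compound 1, `Cc1cc(C2CCC2)c(S(C)(=O)=O)cc1C(=O)N=C(N)N`, gives 8.2 nM.
Compound 2, `Cc1cc(-c2ccc(Cl)cc2)c(S(C)(=O)=O)cc1C(=O)N=C(N)N`, gives 45 nM.
Compound 3, `Cc1cc(-c2cc(Cl)cc(Cl)c2)c(S(C)(=O)=O)cc1C(=O)N=C(N)N`, gives 130 nM.

Compound 3 has the highest of the three numbers, so it is the weakest inhibitor of the set in this assay; its nearest neighbour is compound 2, and compound 1 lies furthest away. Compound 4, `Cc1cc(Sc2ccncc2)c(S(C)(=O)=O)cc1C(=O)N=C(N)N`, differs from compound 3 in one place: (pyridin-4-yl)sulfanyl in place of 3,5-dichlorophenyl on an aromatic carbon.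

Within the data shown here, two measured steps touch the same position. The step of a 16-fold higher number from compound 1 to compound 3 (1.20 log units; beyond the scatter) shows that putting the 3,5-dichlorophenyl group in place of cyclobutyl raised the number strongly, and the step of a 2.9-fold higher number from compound 2 to compound 3 (0.46 log units; beyond the scatter) shows that the second chlorine raised it further, though modestly. Among the measured compounds shown here, no measured step shows a (pyridin-4-yl)sulfanyl group, so the direction can only be guessed from the fact that every group at this position so far gave a different number. Compound 4 is expected to land between compound 1 and compound 3, with an estimated step of a 2.2-fold lower number from compound 3 to compound 4 (0.34 log units; beyond the scatter), and a wide range.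

Compound 4 is estimated at 60 nM, between 12 nM and 300 nM.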

Compound 4, half-maximal inhibitory concentration: 13 nM
Estimate against measurement, compound 4: 4.6-fold (0.66 log units) above, within the range that was stated.
By their numbers in this assay, from the lowest: compounds 1 and 4 (each within the scatter of the next); then compound 2; then compound 3.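

In this assay, replacing the 3,5-dichlorophenyl group with (pyridin-4-yl)sulfanyl gives a 10-fold lower number from compound 3 to compound 4 (1.00 log units; beyond the scatter), and replacing the 4-chlorophenyl group with it gives a 3.5-fold lower number from compound 2 to compound 4 (0.54 log units; beyond the scatter), so a six-membered aromatic ring at this position does not always go with a high number. Against the cyclobutyl group the new group gives a 1.6-fold higher number from compound 1 to compound 4 (0.20 log units; within the scatter), which means compound 4 cannot be told apart from compound 1 in this assay. Nothing available explains why the number changes with this swap.

The new group differs from both chlorophenyl groups in two ways at once, its sulfur link and its ring nitrogen, and the compounds shown cannot separate these two changes. As far as these compounds go, a phenylsulfanyl group or a directly joined pyridin-4-yl ring would pull them apart, and how an amine would behave at this position also remains open.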